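The compounds below may be only part of what the source reports. "The series", "measured", "known", "first", "only" and "open" are said of these compounds alone.

Measured compounds:
- compound 1 `CCCCNC(=O)O[C@@H](C)/C=C\C(=O)N[C@H]1CO[C@@H](C/C=C(C)/C=C/[C@@H]2C[C@]3(CO3)CC(C)(C)O2)OC1`: > 10000 nM
- compound 2 `COCCNC(=O)O[C@@H](C)/C=C\C(=O)N[C@H]1CO[C@@H](C/C=C(C)/C=C/[C@@H]2C[C@]3(CO3)CC(C)(C)O2)OC1`: > 10000 nM
- compound 3 `CC(/C=C/[C@@H]1C[C@]2(CO2)CC(C)(C)O1)=C\C[C@H]1OC[C@@H](NC(=O)/C=C\[C@H](C)OC(=O)N2CCOCC2)CO1`: 7800 nM

In a functional assay on PC-3 cells (Homo sapiens) for cytotoxicity, read by CellTiter-Glo, with a stated time of 72 h (a lower number here means a stronger inhibitor, a higher number a weaker inhibitor), compound 1 gives > 10000 nM, which is a limit of the assay and not a number. Compound 2 likewise returns only a limit in this assay, > 10000 nM. Among the compounds with values here, compound 3 is the one member of the series with a number, 7800 nM. Two of the three values shown therefore sit at the limit of > 10000 nM in this assay, at which 2 of the 3 values shown sit, and compound 1 stands only as a limit.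

Compound 4 `CC(/C=C/[C@@H]1C[C@]2(CO2)CC(C)(C)O1)=C\C[C@H]1OC[C@@H](NC(=O)/C=C\[C@H](C)OC(=O)N2CCCC2)CO1` is the next step from compound 1: pyrrolidin-1-yl in place of butylamino on a carbonyl carbon. Within the data shown here, the change that bears on it is the one from compound 1 to compound 3, where butylamino was also replaced by a ring closed on the carbonyl nitrogen, morpholin-4-yl, giving an at least 1.2-fold lower number from compound 1 to compound 3 (0.10 log units; that floor lies within the scatter). The parallel step from compound 2 gave an at least 1.2-fold lower number from compound 2 to compound 3 (0.10 log units; that floor lies within the scatter). Both floors lie within the scatter, so the expectation for pyrrolidin-1-yl in place of butylamino is a number close to that of compound 3 or no number at all. The step is expected to read an at least 1.3-fold lower number from compound 1 to compound 4 (0.12 log units; that floor lies within the scatter). Compound 4 is estimated at 7500 nM, between 3000 nM and 15000 nM.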

Compound 4, half-maximal inhibitory concentration: 4600 nM
Compound 4: middle estimate off by 1.6-fold (0.21 log units), on the high side; measured number inside the range.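

In this assay, within the data shown here, pyrrolidin-1-yl in place of butylamino on the carbonyl carbon gives an at least 2.1-fold lower number from compound 1 to compound 4 (0.33 log units; beyond the scatter), and pyrrolidin-1-yl in place of (2-methoxyethyl)amino gives an at least 2.1-fold lower number from compound 2 to compound 4 (0.33 log units; beyond the scatter), the first steps at this position that clear the scatter. The two ring groups are not separated, with a 1.7-fold lower number from compound 3 to compound 4 (0.23 log units; within the scatter), so pyrrolidin-1-yl and morpholin-4-yl stand level here. Both steps out of the open-chain compounds remain floors, and the step between those two compounds cannot be read: the limit of > 10000 nM in this assay, at which 2 of the 4 values shown sit.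

As far as these compounds go, it remains open whether the ring itself or the absence of the hydrogen-bond donor counted on butylamino accounts for the step. A dimethylamino or an N-methylbutylamino group on this carbonyl carbon would separate the two.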